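The source may report more compounds than this note shows. Statements on the series, on what has been measured and on what is new or still open speak of the compounds shown alone.

The measured compounds:

Compound 1 `CN1C(=O)/C(=C/C(=O)OC(C)(C)C)c2ccccc21` gives 87.6% in a functional assay on SK-BR-3 cells (Homo sapiens) for inhibition, read by CCK-8 assay, with a stated time of 72 h, tested at 20 uM; on this read-out lower numbers stand for less inhibition of growth and higher numbers for more inhibition of growth at the one concentration tested.
Compound 2 `CC(C)c1ccc2c(c1)/C(=C\C(=O)OC(C)(C)C)C(=O)N2` gives 88.5% in this assay.
Compound 3 `COc1cccc2c1NC(=O)/C2=C/C(=O)OC(C)(C)C` gives 87.7% in this assay.

All three share one core carrying a tert-butyl ester side chain and differ only in what sits on the aromatic ring or on the amide nitrogen. The number for compound 2 is the largest of the three, but the gap to compound 3 and the gap to compound 1 both lie within the scatter of this assay, so the three compounds stand together rather than in any order. On these numbers, substitution around the aromatic ring and at the amide nitrogen has not moved the read-out in a way that can be told from repetition noise.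

Compound 4 `CC(C)(C)OC(=O)/C=C1/C(=O)Nc2ccc([N+](=O)[O-])cc21` has not yet been measured. It differs from compound 2 in one place: nitro in place of isopropyl on an aromatic carbon. For the measured compounds named here, since no step between two measured compounds is available for comparison, the expectation rests on the closeness of the three measured values: the growth inhibition of compound 4 is expected to stay near that of compound 2, with a step of a number 3.5 percentage points lower from compound 2 to compound 4 (within the scatter) that is expected to lie within the scatter or close to it. The estimate for compound 4 is 85%, with a range from 65% to 95%.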

Compound 4, percent growth inhibition at one concentration: 87.9%
Estimate against measurement, compound 4: 2.9 percentage points below, and the stated range covers the measured number.
By their numbers in this assay, from the lowest: compounds 1, 3, 4 and 2 (each within the scatter of the next).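

In this assay, putting nitro in place of isopropyl on this aromatic carbon, meta to a fused ring and para to a fused ring, gives a number 0.6 percentage points lower from compound 2 to compound 4 (within the scatter), and this is the only step shown between two compounds that differ in one place. The earlier compounds shown here could be compared only across differing substitutions, whereas this pair shows directly that an all-carbon group without hydrogen-bond acceptors can give way at this position to a group of nitrogen and oxygen with hydrogen-bond acceptors, with no change that can be told from the scatter. The data offer no measurement that would explain this result.

The compounds shown leave open whether an amine or a carboxylic acid on this aromatic carbon, or a longer chain in place of isopropyl, would stay as close to compound 2, and they do not test any replacement of the tert-butyl ester that all of them carry. Since growth inhibition was read at a single concentration, they also leave open whether compound 2 and compound 4 would stay together at other concentrations.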